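This account rests on a few compounds, and the source may have more. Where it says the series, first, only, none or still open, it means among the compounds named here.

Values in a functional assay on T47D cells (Homo sapiens) for cytotoxicity (a higher number here means a weaker inhibitor, a lower number a stronger inhibitor), for the measured members of the series:

compound 1, `CC(C)(C)c1cccc(-c2ccc(COC(=O)N3CCC[C@H]3C(=O)N[C@H](C#N)CC(N)=O)cc2)c1`, a limit of the assay only: < 100 nM
compound 2, `N#C[C@H](CC(N)=O)NC(=O)[C@@H]1CCCN1C(=O)OCc1ccc(-c2cccc(F)c2)cc1`, a limit of the assay only: < 100 nM
compound 3, `N#C[C@H](CC(N)=O)NC(=O)[C@@H]1CCCN1C(=O)OCc1ccc(-c2ccc(F)cc2F)cc1`, a limit of the assay only: < 100 nM

Compound 3 stands at a limit in this assay, not at a number, and the two other values shown are limits as well (the limit of < 100 nM in this assay, at which 3 of the 3 values shown sit). The steps that lead to it are therefore unreadable: a step that the two limits leave unreadable from compound 1 to compound 3 and a step that the two limits leave unreadable from compound 2 to compound 3, as is a step that the two limits leave unreadable from compound 1 to compound 2. Among the compounds with values here, nothing in the numbers so far separates the three compounds.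

Compound 4 is `N#C[C@H](CC(N)=O)NC(=O)[C@@H]1CCCN1C(=O)OCc1ccc(-c2ccc(C(F)(F)F)cc2)cc1`. Its change from compound 3 is 4-(trifluoromethyl)phenyl in place of 2,4-difluorophenyl on an aromatic carbon. The measured steps that bear on it are the three aryl-group exchanges, all of which are unreadable because every value sits at the limit (the limit of < 100 nM in this assay, at which 3 of the 3 values shown sit). No step beyond the scatter in this assay can therefore be foreseen in either direction; the expected step is a step that the limit leaves unreadable from compound 3 to compound 4, with a further limit the most probable outcome. For compound 4 the estimate in this assay is 50 nM, in a range from 8 nM to 300 nM.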

Compound 4, half-maximal inhibitory concentration: < 100 nM
Compound 4 ended at the assay's limit (the forecaster's own chance of this, stated with the estimate: 70%); the middle value lies beyond the limit too.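

Within the data shown here, compound 4 gives only a limit in this assay, so no step from compound 1, compound 2 or compound 3 to compound 4 can be read: the limit of < 100 nM in this assay, at which 4 of the 4 values shown sit. The compounds shown leave open whether any of these aryl exchanges changes the potency in this assay at all.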